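Cyclopropylmethyl in place of 1-hydroxy-1-methylpropyl: expected affinity

The source may hold more compounds than are shown below. What is called first, only, known or untested is meant among the compounds shown, and "the series" means these compounds.

compound 1 `CCC(CC)Nc1ncnc2c1ncn2C1O[C@H](CO)[C@@H](O)[C@H]1O`: 0.75 nM in an assay on cell membranes for binding affinity to adenosine receptor A1 (Cavia porcellus), read by radioligand binding; on this read-out higher numbers stand for weaker inhibition and lower numbers for stronger inhibition
compound 2 `CCCn1c(=O)c2nc(C(C)(O)CC)[nH]c2n(CCC)c1=O`: 240 nM in this assay

Within the data shown here, of the two numbers in this assay, compound 2 has the highest; its only neighbour, compound 1, sits on a different core and gives a far lower number, a gap well beyond the scatter. Compound 3 `CCCn1c(=O)c2nc(CC3CC3)[nH]c2n(CCC)c1=O` keeps the core of compound 2 and differs by cyclopropylmethyl in place of 1-hydroxy-1-methylpropyl on an aromatic carbon. Among the measured compounds shown here, no measured pair shows this change, so its size rests on expectation alone: a decrease beyond the scatter in this assay is expected, a 6.0-fold lower number from compound 2 to compound 3 (0.78 log units; beyond the scatter). For compound 3 the estimate in this assay is 40 nM, within 10 nM to 160 nM.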

Compound 3, inhibition constant: 120 nM
Beside the measured number, compound 3's estimate is 3.0-fold (0.48 log units) below it; low and high end bracket the measured number.
By their numbers in this assay, from the lowest: compound 1; then compounds 3 and 2 (each within the scatter of the next).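

At this position, on an aromatic carbon of the shared core, cyclopropylmethyl in place of 1-hydroxy-1-methylpropyl gives in this assay a 2.0-fold lower number from compound 2 to compound 3 (0.30 log units; within the scatter) as the first step read here. The hydroxyl, with its hydrogen-bond donor and acceptor, can therefore go and a three-membered ring can enter without a shift beyond the scatter in this read-out. No measured evidence accounts for this result.

As far as these compounds go, whether an amine, a carboxylic acid or a longer chain at this place would move the number beyond the scatter remains open.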